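The compounds below may be only part of what the source reports. "The series", "measured", "known", "first", "only" and "open" are said of these compounds alone.

Measured so far:
- compound 1 `Cc1nn(-c2ccccn2)c2cc(-c3ccc(CCC(=O)O)cc3)ccc12`: 1400 nM
- compound 2 `Cc1nn(-c2ccccn2)c2cc(-c3cccc(CCC(=O)O)c3)ccc12`: the assay gives only a limit, > 100000 nM
- compound 3 `Cc1nn(-c2ccccn2)c2cc(-c3ccc(CCC(=O)O)cc3)ncc12`: 9200 nM

In a functional assay on cells for agonist activity at Free fatty acid receptor 1 (Mus musculus), read by FLIPR and calcium flux, with a stated time of 5 min (on this read-out higher numbers stand for an effect only at larger amounts of compound and lower numbers for an effect already at smaller amounts), compound 1 stands at the lowest of the two numbers; the nearest is compound 3, whose number is higher by a margin beyond the scatter. Compound 2 sits at a limit of > 100000 nM in this assay, at which 1 of the 3 values shown sits, and gives no number.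

Compound 4 `Cc1nn(-c2ccccn2)c2cc(-c3ccc(CCC(=O)O)cc3Cl)ccc12` differs from compound 1 by chloro in place of hydrogen on an aromatic carbon, in words: chloro in place of hydrogen on an aromatic carbon. Within the data shown here, no measured pair shows this change, so its size is open. The step is expected to be small, toward a lower number and within the scatter: a 1.6-fold lower number from compound 1 to compound 4 (0.19 log units; within the scatter). Compound 4 is thus estimated at 900 nM, in a range from 300 nM to 3000 nM.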

Compound 4, half-maximal effective concentration: 1200 nM
Compound 4: middle estimate off by 1.3-fold (0.12 log units), on the low side, within the range that was stated.
By their numbers in this assay, from the lowest: compounds 4 and 1 (each within the scatter of the next); then compound 3. At a limit, above all of these: compound 2.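

In this assay, the step for chloro in place of hydrogen on an aromatic carbon, ortho to a large group and meta to a 2-carboxyethyl group, is a 1.2-fold lower number from compound 1 to compound 4 (0.07 log units; within the scatter) and so shows no change. Among these compounds, compound 1, compound 2 and compound 3 carry no group at this place, so this is the first reading of a substituent there. Nothing given bears on why the step has this size.

On these data alone, whether this place also tolerates a larger or different group, such as methoxy, an amine or a longer chain, stays open.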